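A few compounds are considered here, and "the series" means these few. Any claim that something is new, unique, unknown or untested is made for them only; others in the source may bear on it.

Measured compounds in a functional assay on MCF7 cells (Homo sapiens) for inhibition, read by sulforhodamine B assay, with a stated time of 48 h; on this read-out lower numbers stand for stronger inhibition of growth and higher numbers for weaker inhibition of growth:
- compound 1 `COc1cc(-c2cc(/C=C/C(=O)c3ccc(N)cc3)[nH]n2)cc(OC)c1OC`: 1500 nM
- compound 2 `COc1ccc(-c2cc(/C=C/C(=O)c3ccc(OC)c(OC)c3)[nH]n2)cc1`: 410 nM
- compound 3 `COc1cc(-c2cc(/C=C/C(=O)c3ccc(Cl)c(Cl)c3)[nH]n2)cc(OC)c1OC`: 1800 nM

Compound 1 stands second highest of the three numbers in this assay. Within the data shown here, its nearest neighbour is compound 3, with a 1.2-fold higher number from compound 1 to compound 3 (0.08 log units; within the scatter); its furthest is compound 2, whose number is lower by a margin beyond the scatter, although compound 2 differs from compound 1 at both aryl groups, so no single-change step links them.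

Compound 4 `COc1ccc(-c2cc(/C=C/C(=O)c3ccc(N)cc3)[nH]n2)cc1OC` has not yet been measured. Relative to compound 1 the change is hydrogen in place of methoxy on an aromatic carbon. This change sits on the aryl ring attached to the shared core, not on the carbonyl side. Among the measured compounds shown here, the only measured single-change step, from compound 1 to compound 3, alters the carbonyl-side aryl and lies within the scatter, so it does not bear on the change to compound 4. The pair compound 1 and compound 2 shows a lower number with fewer methoxy groups on the core-side ring, but the carbonyl-side ring also changes there, so the contribution of the methoxy removal alone cannot be separated.

The expectation for compound 4 in this assay is therefore a small step toward a lower number, a 1.5-fold lower number from compound 1 to compound 4 (0.18 log units; within the scatter), that may well stay within the scatter. Compound 4 is estimated at 1000 nM, with a range of 400 nM to 2500 nM.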

Compound 4, concentration for 50% growth inhibition: 2280 nM
Compound 4: middle estimate off by 2.3-fold (0.36 log units), on the low side; low and high end bracket the measured number.
By their numbers in this assay, from the lowest: compound 2; then compounds 1, 3 and 4 (each within the scatter of the next).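

In this assay, the step on the aryl ring attached to the shared core, a 1.5-fold higher number from compound 1 to compound 4 (0.18 log units; within the scatter), shows that the methoxy ortho to a methoxy group and meta to a large group can be replaced by hydrogen without separating compound 4 from compound 1, with the 4-aminophenyl on the carbonyl side held the same. Read with the earlier step, a 1.2-fold higher number from compound 1 to compound 3 (0.08 log units; within the scatter), this gives one single-place replacement on each aryl group of compound 1, and both lie within the scatter. Nothing on hand explains why this methoxy can be replaced in this way.

The compounds shown leave open whether the same replacement would read alike with a different aryl group on the carbonyl side, such as the 3,4-dichlorophenyl of compound 3. Also open, on these data alone, is whether a hydroxyl or a fluorine at this position, or an ethoxy in place of the methoxy, would stay as close to compound 1 as hydrogen does.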